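Acid headgroup swap: from compound 1 to compound 4

A few compounds are considered here, and "the series" means these few. Any claim that something is new, unique, unknown or untested is made for them only; others in the source may bear on it.

Measured so far:
- compound 1 `O=C(O)C12CC(CN3CCC[C@H](O[C@H](CO)c4cc(Cl)cc(Cl)c4)[C@@H]3c3ccccc3)(C1)C2`: > 200000 nM
- compound 2 `CC(=O)NS(=O)(=O)c1ccc(CN2CCC[C@H](O[C@H](CO)c3cc(Cl)cc(Cl)c3)[C@@H]2c2ccccc2)cc1`: > 200000 nM
- compound 3 `Cc1cc(C(=O)O)ccc1CN1CCC[C@H](O[C@H](CO)c2cc(Cl)cc(Cl)c2)[C@@H]1C1CCCCC1`: > 200000 nM

The read-out throughout is an assay on isolated protein for activation of cGMP-dependent protein kinase 1 (Homo sapiens), read by ADP-Glo, with stated times of 30 min and 2 h; a lower number here means that less compound is needed, a higher number that more compound is needed for the effect. For compound 1 the value given is a limit of the assay, not a number. The value of compound 2 is likewise a limit. The value of compound 3 is also a limit. Compound 1 therefore stands at the same limit as the other two; no order among the three can be drawn, since (the limit of > 200000 nM in this assay, at which 3 of the 3 values shown sit).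

The next compound, compound 4 `O=C(O)c1ccc(CN2CCC[C@H](O[C@H](CO)c3cc(Cl)cc(Cl)c3)[C@@H]2c2ccccc2)c([N+](=O)[O-])c1`, is compound 1 with a group of 12 heavy atoms (7 carbon, 1 nitrogen, 4 oxygen; one six-membered aromatic ring of carbon only) in place of a group of 8 heavy atoms (6 carbon, 2 oxygen; 2 four-membered non-aromatic rings of carbon only), on a saturated chain carbon bound to an amine nitrogen in a ring. Among the compounds with values here, no measured pair in this set differs in one place only, so the size of this kind of step has not been observed here. With every measured value sitting at the limit, no direction of change can be taken from the data; the expectation is a step of a number no higher from compound 1 to compound 4 (the limit leaves the size open), that is no movement beyond the scatter and most likely another limit. For compound 4 the estimated value in this assay is 200000 nM, with a range from 50000 nM to 600000 nM.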

Compound 4, half-maximal effective concentration: 13000 nM
For compound 4 the middle estimate is 15-fold (1.19 log units) above the measured one, outside the stated range (below it).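

In this assay, the place on a saturated chain carbon bound to an amine nitrogen in a ring turns out to be able to move the read-out: putting 4-carboxy-2-nitrophenyl there gives an at least 15-fold lower number from compound 1 to compound 4 (1.18 log units; beyond the scatter). Within the data shown here, compound 4, at 13000 nM, holds the first value that is a number and not a limit of the assay, so the series now has a measured starting point. Compound 1 stands at a limit, so the step fixes only a minimum size for the change: the limit of > 200000 nM in this assay, at which 3 of the 4 values shown sit.

The change swaps the ring and brings in the nitro group in one step, and the compounds shown do not separate the two. From the compounds shown here alone, whether 4-carboxyphenyl alone, or a version carrying an amine or a methoxy group instead of the nitro group, would give a similar number stays open.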